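Urea to amide: expected weakening of cell growth inhibition

This account rests on a few compounds, and the source may have more. Where it says the series, first, only, none or still open, it means among the compounds named here.

Measured compounds in a functional assay on OVCAR-4 cells (Homo sapiens) for inhibition, read by sulforhodamine B assay, with a stated time of 48 h, tested at 10 uM; on this read-out lower numbers stand for a stronger effect and higher numbers for a weaker effect at the one concentration tested:
compound 1 `COc1cc(Cl)cc(-c2nn(-c3cccc(NC(=O)c4ccc(Cl)c(Cl)c4)c3)cc2-c2ccncc2)c1` gives 58.6%
compound 2 `COc1cc(Cl)cc(-c2nn(-c3cccc(NC(=O)Nc4ccc(Cl)c(Cl)c4)c3)cc2-c2ccncc2)c1` gives 13.3%
compound 3 `COc1cc(Cl)cc(-c2nn(-c3cccc(NC(=O)Nc4cccc(C(F)(F)F)c4)c3)cc2-c2ccncc2)c1` gives 3.28%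

Compound 3 has the lowest number of the three in this assay. Its nearest neighbour is compound 2, as the step of a number 10 percentage points lower from compound 2 to compound 3 (within the scatter) shows; the furthest is compound 1, as the step of a number 55.3 percentage points lower from compound 1 to compound 3 (beyond the scatter) shows.

Compound 4 `COc1cc(Cl)cc(-c2nn(-c3cccc(NC(=O)c4cccc(C(F)(F)F)c4)c3)cc2-c2ccncc2)c1` has not been measured. It differs from compound 3 in one place: 3-(trifluoromethyl)phenyl in place of (3-(trifluoromethyl)phenyl)amino on a carbonyl carbon

For the measured compounds named here, two measured steps bear on this change, both running in the opposite direction, from an aryl group on the carbonyl carbon to an arylamino group: a number 45.3 percentage points lower from compound 1 to compound 2 (beyond the scatter) and a number 55.3 percentage points lower from compound 1 to compound 3 (beyond the scatter). Both were large and lowered the number. Going back from the arylamino group to the aryl group in compound 4 is therefore expected to raise the number by a large step, a number 48.7 percentage points higher from compound 3 to compound 4 (beyond the scatter), landing near where compound 1 stands.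

For compound 4 the value in this assay is estimated at 52%, with a range from 25% to 80%.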

Compound 4, a percentage reported as activity, at one concentration (the size of the read-out at that concentration, not a potency): 71.8%
The estimate for compound 4 lay 19.8 percentage points below the measured number, within the range that was stated.
By their numbers in this assay, from the lowest: compounds 3 and 2 (each within the scatter of the next); then compound 1; then compound 4.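

With the 3-(trifluoromethyl)phenyl group held fixed, losing the amino nitrogen on the carbonyl carbon gives a number 68.5 percentage points higher from compound 3 to compound 4 (beyond the scatter) in this assay, so the loss first seen with the 3,4-dichlorophenyl pair now appears with a second aryl group; a number 58.5 percentage points higher from compound 2 to compound 4 (beyond the scatter) runs the same way, although that pair also differs in its aryl group. The choice of aryl group is also now visible among the amides, with a number 13.2 percentage points higher from compound 1 to compound 4 (beyond the scatter), whereas the same swap among the ureas stayed within the scatter. No measurement here explains why the urea outperforms the amide.

Still open, from the compounds shown here alone, is whether other links on the same aryl groups, such as a carbamate or a sulfonamide, behave like the urea or the amide. It is also unknown how an aryl ring carrying an amine or a carboxylic acid would fare.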